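From propyl to isobutyl on a shared core

The source may report more compounds than this note shows. Statements on the series, on what has been measured and on what is new or still open speak of the compounds shown alone.

- Compound 1 `CCC[C@H]1O[C@H](COCc2ccccc2)[C@@H](OCc2ccccc2)[C@H](OCc2ccccc2)[C@H]1O`: 17400 nM
- Compound 2 `CCC[C@@H]1O[C@H](COCc2ccccc2)[C@@H](OCc2ccccc2)[C@H](OCc2ccccc2)[C@@H]1O`: 23300 nM

In a functional assay on HeLa cells (Homo sapiens) for antiproliferative activity, read by sulforhodamine B assay (on this read-out higher numbers stand for weaker inhibition of growth and lower numbers for stronger inhibition of growth), compound 2 gives 23300 nM, which lies within the scatter of compound 1. Compound 3 `CC(C)C[C@@H]1O[C@H](COCc2ccccc2)[C@@H](OCc2ccccc2)[C@H](OCc2ccccc2)[C@@H]1O` turns propyl into isobutyl, with methyl in place of hydrogen on a saturated chain carbon bound to two saturated chain carbons. Going by the values given here, the only measured step, a 1.3-fold higher number from compound 1 to compound 2 (0.13 log units; within the scatter), comes with the fact that compounds 1 and 2 differ only in the configuration as drawn. It is small, and it tests no change of chain, so it offers only weak guidance. No shift beyond the scatter is therefore expected, though the uncertainty is wide. The expected change is a 1.2-fold lower number from compound 2 to compound 3 (0.07 log units; within the scatter). For compound 3 the estimate is 20000 nM, with a range of 8000 nM to 50000 nM.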

Compound 3, concentration for 50% growth inhibition: 24600 nM
The estimate for compound 3 lay 1.2-fold (0.09 log units) below the measured number; measured number inside the range.
By their numbers in this assay, from the lowest: compounds 1, 2 and 3 (each within the scatter of the next).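

In this assay the change from propyl to isobutyl, methyl in place of hydrogen on a saturated chain carbon bound to two saturated chain carbons, gives a 1.1-fold higher number from compound 2 to compound 3 (0.02 log units; within the scatter). This is the only change of chain among these compounds, and it shows that this one added methyl leaves growth inhibition within the scatter. No evidence at hand bears on this chain change.

As far as these compounds go, whether a longer chain, a phenyl ring or an amine in this place would shift the number stays open. So does whether isobutyl would behave the same on the configuration of compound 1.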